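Methyl in place of bromo: a small expected step

The source may report more compounds than this note shows. Statements on the series, on what has been measured and on what is new or still open speak of the compounds shown alone.

Values in a functional assay on A549 cells (Homo sapiens) for antiproliferative activity, read by MTT assay, with a stated time of 48 h; a higher number here means a weaker inhibitor, a lower number a stronger inhibitor:
compound 1 `COc1ccc(-c2nc3cccc(-c4cc(OC)c(OC)c(OC)c4)c3o2)cc1`: 2200 nM
compound 2 `COc1cc(-c2cccc3nc(-c4cccc(Br)c4)oc23)cc(OC)c1OC`: 2100 nM

Among the compounds with values here, compound 2 has only one measured neighbour, and the two numbers agree within the scatter, so neither compound can be ranked above the other. The compound now in question is compound 3 `COc1cc(-c2cccc3nc(-c4cccc(C)c4)oc23)cc(OC)c1OC`, which differs from compound 2 in a single substituent: methyl in place of bromo on an aromatic carbon. In words, this is methyl in place of bromo on an aromatic carbon, which turns 3-bromophenyl into 3-methylphenyl.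

Within the data shown here, only one measured step bears on this swap. It exchanged the whole aromatic group that carries the bromo, a larger edit than the one at hand, and still a 1.0-fold lower number from compound 1 to compound 2 (0.02 log units; within the scatter). One step is thin evidence, but it gives no reason to expect a real shift in either direction in this assay, so no step beyond the scatter is expected. The estimated change is small: no change at the digits printed from compound 2 to compound 3 (within the scatter). For compound 3 the estimated value is 2100 nM, with an expected range from 1000 nM to 4500 nM.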

Compound 3, half-maximal inhibitory concentration: 16700 nM
Beside the measured number, compound 3's estimate is 8.0-fold (0.90 log units) below it; the measured number lies above the stated range.
By their numbers in this assay, from the lowest: compounds 2 and 1 (each within the scatter of the next); then compound 3.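

In this assay this position turns out to be sensitive: one heavy atom replaces one heavy atom, with no ring, hydrogen-bond donor, hydrogen-bond acceptor or net charge on either side, and still the swap gives an 8.0-fold higher number from compound 2 to compound 3 (0.90 log units; beyond the scatter). The earlier pair could have suggested that the aromatic group tolerates change, since it showed a 1.0-fold lower number from compound 1 to compound 2 (0.02 log units; within the scatter), but the 3-methylphenyl compound breaks that picture with a 7.6-fold higher number from compound 1 to compound 3 (0.88 log units; beyond the scatter), so the match between compound 1 and compound 2 does not extend to every aryl group. No measurement at hand explains why so small an exchange matters in this assay.

The compounds shown cannot tell whether bromo is the unusual group here or methyl is, since only these two substituents have been compared at this place on the ring. A chloro or trifluoromethyl group, or an amine or a carboxylic acid, at the same place would show whether the number stays near that of compound 2, moves toward that of compound 3, or goes somewhere else.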